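The source may hold more compounds than are shown below. What is called first, only, known or untested is meant among the compounds shown, and "the series" means these compounds.

Measured compounds in a functional assay on HCT-15 cells (Homo sapiens) for cytotoxicity, read by CCK-8 assay and cell counting, with a stated time of 72 h; a lower number here means a stronger inhibitor, a higher number a weaker inhibitor:
Compound 1, `COc1ccc(-c2cc3ccccc3c(-c3cccc(N)c3)n2)cc1`, gives 2350 nM.
Compound 2, `COc1ccc(-c2cc3ccccc3c(-c3ccc(O)cc3)n2)cc1`, gives only a limit of the assay, > 50000 nM.
Compound 3, `COc1cc(OC)cc(-c2cc3ccccc3c(-c3cccc(N)c3)n2)c1`, gives 4080 nM.

The one counted change among these, (4-hydroxyphenyl in place of 3-aminophenyl on an aromatic carbon), produces an at least 21-fold higher number from compound 1 to compound 2 (1.32 log units; beyond the scatter). Its size is known only as a lower bound due to the limit of > 50000 nM in this assay, at which 1 of the 3 values shown sits, since the number for compound 2 is a limit rather than a measured value. Compound 1 and compound 3 differ in their cores in a way that is not broken down here, and their values lie within the scatter of each other.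

Compound 4, `COc1cc(OC)cc(-c2cc3ccccc3c(-c3ccc(O)cc3)n2)c1`, has not yet been measured. It stands to compound 3 as compound 2 stands to compound 1: 4-hydroxyphenyl in place of 3-aminophenyl on an aromatic carbon. The surroundings are described slightly differently, meta to a large group rather than meta to a 4-methoxyphenyl group (8 heavy atoms), so this is the same kind of change, not the same one. Resting on the step observed from compound 1 to compound 2, the number for compound 4 is expected to rise by a 15-fold higher number from compound 3 to compound 4 (1.17 log units; beyond the scatter). Compound 4 is therefore estimated at 60000 nM, probably again reported only as a limit, between 20000 nM and 200000 nM.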

Compound 4, half-maximal inhibitory concentration: 2780 nM
Estimate against measurement, compound 4: 22-fold (1.33 log units) above, outside the stated range (below it).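

In this assay, the change to 4-hydroxyphenyl in place of 3-aminophenyl does not carry over from the core of compound 1 to the core of compound 3: on the second core it gives a 1.5-fold lower number from compound 3 to compound 4 (0.17 log units; within the scatter), and the two steps differ: the same change on two cores in this assay, an at least 21-fold higher number (1.32 log units; beyond the scatter) from compound 1 to compound 2 and a 1.5-fold lower number (0.17 log units; within the scatter) from compound 3 to compound 4, at least 31-fold (1.49 log units) apart, beyond the scatter of two such steps

Compound 2 gives > 50000 nM, which is a limit of the assay and not a number, so the first step has no measured size, only a lower bound: the limit of > 50000 nM in this assay, at which 1 of the 4 values shown sits.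

The two pairs show that the outcome of this change depends on the core in these compounds, but they do not show which feature of the cores is responsible or what the change would do on any further core.

The compounds shown leave open whether 3-hydroxyphenyl or 4-aminophenyl at the same place would behave like either group here, since the two groups compared differ in both the atom and its place on the ring. They also leave open how a carboxylic acid or an amide there would fare on either core.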